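Amino in Place of Chloro: Expectation for Compound 4

The compounds below may be only part of what the source reports. "The series", "measured", "known", "first", "only" and "open" are said of these compounds alone.

compound 1 `ClCc1ccccc1Cn1cnc2c(Cl)nc(Cl)nc21` — 970 nM
compound 2 `Nc1nc(Cl)c2ncn(Cc3ccc(CCl)cc3)c2n1` — > 100000 nM, a limit of the assay
compound 3 `ClCc1ccc(Cn2cnc3nc(Cl)nc(Cl)c32)cc1` — "not determined" (no result reported)

For the measured compounds named here, in a functional assay on HOP-92 cells (Homo sapiens) for cytotoxicity, read by sulforhodamine B assay, with a stated time of 48 h (on this read-out higher numbers stand for weaker inhibition of growth and lower numbers for stronger inhibition of growth), compound 1 gives 970 nM, the only plain number among the three entries. Compound 2 reaches only a limit, > 100000 nM, and the record notes that (the limit of > 100000 nM in this assay, at which 1 of the 3 values shown sits). For compound 3 the entry reads "not determined" (no result reported).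

Compound 4 `Nc1nc(Cl)c2ncn(Cc3ccccc3CCl)c2n1` differs from compound 1 by amino in place of chloro on an aromatic carbon. Compound 2 carries the same amino group, and in this assay it shows only a limit. On that basis the step of a 21-fold higher number from compound 1 to compound 4 (1.31 log units; beyond the scatter) is expected to weaken growth inhibition clearly beyond the scatter. Compound 4 is estimated at 20000 nM, between 3000 nM and 100000 nM.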

Compound 4, concentration for total growth inhibition: 30900 nM
Beside the measured number, compound 4's estimate is 1.5-fold (0.19 log units) below it; measured number inside the range.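

In this assay, amino in place of chloro on the aromatic carbon between two ring nitrogen atoms gives a 32-fold higher number from compound 1 to compound 4 (1.50 log units; beyond the scatter), a large step. Compound 4 thus puts a plain number on an amino compound, which the earlier entries did not offer. Compound 2, which carries the same amino group, gives only a limit of the assay: the limit of > 100000 nM in this assay, at which 1 of the 4 values shown sits.

The compounds shown leave open whether a methylamino or a hydroxyl group at this position would stay closer to compound 1. Compound 3 has no reported result, so the step from compound 3 to compound 2 cannot be read.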